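A few compounds are considered here, and "the series" means these few. Any claim that something is new, unique, unknown or untested is made for them only; others in the source may bear on it.

Compound 1 `CCCCCNc1cnc(C(=O)NCc2ccccc2)cn1`: in an ADME assay on HeLa cells (Homo sapiens) for cytotoxicity, read by microscopy, with a stated time of 6 days (on this read-out higher numbers stand for lower toxicity in this test and lower numbers for higher toxicity in this test), compound 1 gives > 100000 nM, which is a limit of the assay.
Compound 2 `CCCCCCNc1cnc(C(=O)NCc2ccccc2)cn1`: in this assay compound 2 gives > 100000 nM, again a limit of the assay.
Compound 3 `CCCCCCNc1nccnc1C(=O)NCc1ccccc1`: in this assay compound 3 gives > 100000 nM, also a limit of the assay.

Compound 1 and compound 2 differ in one place, by methyl in place of hydrogen on a saturated chain carbon, five bonds along the chain from a nitrogen on an aromatic ring. The step that the two limits leave unreadable from compound 1 to compound 2 cannot be sized, because both values sit at the limit of > 100000 nM in this assay, at which 3 of the 3 values shown sit. Compound 3 carries a different core from compound 1; the difference between the two cores is not broken down here. Compound 4 `CCCCCCCNc1nccnc1C(=O)NCc1ccccc1` is not yet measured, and it stands to compound 3 as compound 2 stands to compound 1: the change is methyl in place of hydrogen on a saturated chain carbon, six bonds along the chain from a nitrogen on an aromatic ring. This is the same kind of change, not the same one, since in compound 4 the new methyl sits six bonds along the chain from a nitrogen on an aromatic ring, whereas in compound 2 it sits five bonds along.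

For compound 4 in this assay the expected step is a step that the limit leaves unreadable from compound 3 to compound 4, which rests on the unreadable step that the two limits leave unreadable from compound 1 to compound 2 and on the fact that compound 3 gives only a limit, > 100000 nM. Compound 4 is therefore estimated at 150000 nM, between 60000 nM and 400000 nM, with the expectation that the assay will most likely again report only a limit.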

Compound 4, minimum cytotoxic concentration: > 100000 nM
Compound 4: a limit, no number (the forecaster's own chance of this, stated with the estimate: 85%); the middle value is on the limit's open side.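

In this assay compound 4 gives > 100000 nM, which is again a limit of the assay. No step can be read from compound 3 to compound 4, because both values sit at the same limit: the limit of > 100000 nM in this assay, at which 4 of the 4 values shown sit.

The compounds shown leave open whether lengthening the chain or changing the core alters the minimum cytotoxic concentration in this assay, and at what concentration any of them would turn toxic.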